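A methyl shift from compound 1 to compound 4

This account rests on a few compounds, and the source may have more. Where it says the series, first, only, none or still open, it means among the compounds named here.

Measured in a functional assay on MCF7 cells (Homo sapiens) for antiproliferative activity, read by MTT assay, with a stated time of 72 h; on this read-out higher numbers stand for weaker inhibition and lower numbers for stronger inhibition:
- compound 1 `CCCNC(=O)c1cc(Oc2ccc(NC(=O)c3nn(-c4ccc(C)cc4)c(=O)cc3C)cc2F)ccn1`: 34600 nM
- compound 2 `CCNC(=O)c1cc(Oc2ccc(NC(=O)c3nn(-c4cccc(F)c4)c(=O)cc3C)cc2)ccn1`: 18900 nM
- compound 3 `CCNC(=O)c1cc(Oc2ccc(NC(=O)c3nn(-c4ccc(C)cc4)c(=O)cc3C)cc2)ccn1`: 51300 nM

The value of compound 1 lies within the scatter of both compound 2 and compound 3, and those two stand apart from each other. Compound 4 `CCCNC(=O)c1cc(Oc2ccc(NC(=O)c3nn(-c4ccccc4C)c(=O)cc3C)cc2F)ccn1` is the unmeasured isomer of compound 1, with 2-methylphenyl in place of 4-methylphenyl on an aromatic nitrogen. For the measured compounds named here, only one measured step changes a group at that nitrogen, a 2.7-fold higher number from compound 2 to compound 3 (0.43 log units; beyond the scatter), and it swaps 3-fluorophenyl for 4-methylphenyl. Going by the values given here, no measured step moves the methyl group, so no shift beyond the scatter is expected in this assay. The estimated change is a 1.2-fold lower number from compound 1 to compound 4 (0.06 log units; within the scatter). For compound 4 the expected value is 30000 nM, with an estimated range of 12000 nM to 70000 nM.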

Compound 4, half-maximal inhibitory concentration: 39600 nM
Compound 4: the middle estimate sits 1.3-fold (0.12 log units) below what was measured; low and high end bracket the measured number.
By their numbers in this assay, from the lowest: compounds 2, 1, 4 and 3 (each within the scatter of the next, the first and the last beyond it).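

In this assay, the change from 4-methylphenyl to 2-methylphenyl on the aromatic nitrogen gives a 1.1-fold higher number from compound 1 to compound 4 (0.06 log units; within the scatter), so with this core the place of the methyl group on that phenyl ring does not separate the two isomers. The earlier compounds had shown only an exchange of one substituted phenyl for another, never a moved methyl group. Nothing available explains this result. From the compounds shown here alone, it remains open whether an ethyl or a methoxy group in place of that methyl group would shift the number. Going by these compounds, it is also open whether the same move would behave alike on the core of compound 3.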